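This account rests on a few compounds, and the source may have more. Where it says the series, first, only, none or still open, it means among the compounds named here.

Compound 2 `Cc1cc(N2CC[C@@H](C)[C@@H](N(C)c3ncnc4[nH]ccc34)C2)n2nc(SCC3CCCCC3)nc2n1` gives 98200 nM in a toxicity assay on GES1 cells (Homo sapiens) for inhibition, read by MTT assay, with a stated time of 72 h; on this read-out higher numbers stand for weaker inhibition and lower numbers for stronger inhibition. Among the numbers shown it is the higher of two, and the nearest to it is compound 1 `Cc1cc(N2CC[C@@H](C)[C@@H](N(C)c3ncnc4[nH]ccc34)C2)n2ncnc2n1`, which gives 57900 nM in this assay; the step of a 1.7-fold higher number from compound 1 to compound 2 (0.23 log units; within the scatter), brought about by (cyclohexylmethyl)sulfanyl in place of hydrogen on an aromatic carbon, stays within the scatter. Compound 3 `CCc1cc(N2CC[C@@H](C)[C@@H](N(C)c3ncnc4[nH]ccc34)C2)n2ncnc2n1` gives > 100000 nM in this assay, which is a limit of the assay rather than a number. The step of an at least 1.7-fold higher number from compound 1 to compound 3 (0.23 log units; that floor lies within the scatter) comes from methyl in place of hydrogen on a saturated chain carbon bound to an aromatic carbon.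

Compound 4 `Cc1cc(N2CC[C@@H](C)[C@@H](N(C)c3ncnc4[nH]ccc34)C2)n2nc(SCc3ccccc3Br)nc2n1` differs from compound 2 by 2-bromophenyl in place of cyclohexyl on a saturated chain carbon bound to a sulfur. Neither measured step touches the group that changes here; what can be said is that adding the whole (cyclohexylmethyl)sulfanyl group moved nothing beyond the scatter. Compound 4 is therefore expected to show a step of a 1.1-fold lower number from compound 2 to compound 4 (0.04 log units; within the scatter) that remains within the scatter. The estimate for compound 4 is 90000 nM, with a range from 40000 nM to 200000 nM.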

Compound 4, half-maximal inhibitory concentration: > 100000 nM
Compound 4 ended at the assay's limit (the forecaster's own chance of this, stated with the estimate: 40%); middle value at least 1.1-fold (0.04 log units) away from the limit.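

Among the compounds shown here, compound 4 shows what the earlier compounds could not: at the saturated chain carbon bound to a sulfur, a ring other than cyclohexyl, here the aromatic 2-bromophenyl, still gives no lower number in this assay. Its result is a limit of the assay and not a number. The steps can therefore be read only as floors, an at least 1.0-fold higher number from compound 2 to compound 4 (0.00 log units; that floor lies within the scatter) and an at least 1.7-fold higher number from compound 1 to compound 4 (0.23 log units; that floor lies within the scatter), so neither shows a change beyond the scatter, and their true size stays unknown: the limit of > 100000 nM in this assay, at which 2 of the 4 values shown sit.

Going by these compounds, what number compound 4 would give past this limit remains open. So does whether an amine or a carboxylic acid in place of the bromine, or a longer chain in place of the benzyl group, would give a number within the range of the assay.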